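Swapping the aryl on the amino nitrogen of compound 3

This account rests on a few compounds, and the source may have more. Where it says the series, first, only, none or still open, it means among the compounds named here.

Compound 3 `Cc1ccc(Nc2nc(SCc3cn(CC(=O)NC(=O)Nc4ccccn4)nn3)nc(-c3ccc(C)cc3)c2C#N)cc1` gives 39600 nM in a functional assay on MCF7 cells (Homo sapiens) for inhibition, read by MTT assay, with a stated time of 72 h (on this read-out lower numbers stand for stronger inhibition and higher numbers for weaker inhibition), the higher of the two numbers measured, with compound 1 `CC(C)c1ccc(-c2nc(SCc3cn(CC(=O)NC(=O)Nc4ccccn4)nn3)nc(Nc3cccc(C(F)(F)F)c3)c2C#N)cc1` nearer at 8620 nM. Compound 2 `Cc1ccc(-c2nc(SCc3cn(CC(=O)NC(=O)Nc4ccccn4)nn3)nc(Nc3ccc(C(C)C)cc3)c2C#N)cc1` reaches the limit > 64000 nM in this assay. Within the data shown here, the step of an at least 1.6-fold lower number from compound 2 to compound 3 (0.20 log units; that floor lies within the scatter) is the one measured change, and it sits at a different place than the change considered here. Compound 4 `Cc1ccc(-c2nc(SCc3cn(CC(=O)NC(=O)Nc4ccccn4)nn3)nc(Nc3cccc(C(F)(F)F)c3)c2C#N)cc1` differs from compound 3 by 3-(trifluoromethyl)phenyl in place of 4-methylphenyl on a nitrogen on an aromatic ring. No measured pair shows this exact change; compound 1 carries the same 3-(trifluoromethyl)phenyl on that nitrogen and gives the lowest number shown. Compound 4 is therefore expected to give a lower number than compound 3, a step of a 2.6-fold lower number from compound 3 to compound 4 (0.42 log units; beyond the scatter). The estimate for compound 4 is 15000 nM, between 4000 nM and 50000 nM.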

Compound 4, half-maximal inhibitory concentration: 6120 nM
Estimate against measurement, compound 4: 2.5-fold (0.39 log units) above; measured number inside the range.
By their numbers in this assay, from the lowest: compounds 4 and 1 (each within the scatter of the next); then compound 3. At a limit, above all of these: compound 2.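

On the nitrogen on an aromatic ring, 3-(trifluoromethyl)phenyl in place of 4-methylphenyl gives a 6.5-fold lower number from compound 3 to compound 4 (0.81 log units; beyond the scatter) in this assay, which puts a measured size on this change. In place of 4-isopropylphenyl it gives an at least 10-fold lower number from compound 2 to compound 4 (1.01 log units; beyond the scatter), which is only a floor, as compound 2 stands at a limit: the limit of > 64000 nM in this assay, at which 1 of the 4 values shown sits. Methyl in place of isopropyl on the other aryl gives a 1.4-fold lower number from compound 1 to compound 4 (0.15 log units; within the scatter), so the 3-(trifluoromethyl)phenyl result holds on both cores: the same change on two cores in this assay, an at least 1.6-fold lower number (0.20 log units; that floor lies within the scatter) from compound 2 to compound 3 and a 1.4-fold lower number (0.15 log units; within the scatter) from compound 1 to compound 4; the limit leaves it open whether they differ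

Going by these compounds, whether the step follows from the trifluoromethyl group itself or from where it sits on the ring stays open. A 4-(trifluoromethyl)phenyl or a 3-methylphenyl on that nitrogen would separate the two.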